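The source may hold more compounds than are shown below. What is called first, only, known or untested is meant among the compounds shown, and "the series" means these compounds.

Measured so far in a functional assay on OVCAR-8 cells (Homo sapiens) for antiproliferative activity, read by sulforhodamine B assay, with a stated time of 48 h; on this read-out lower numbers stand for higher toxicity in this test and higher numbers for lower toxicity in this test:
compound 1, `COc1ccc(OC)c(/C=C/c2nnc(Nc3ccc(Cl)cc3)o2)c1`, gives 76400 nM
compound 2, `COc1ccc(OC)c(/C=C/C(=O)N/N=C/c2ccc(Cl)cc2)c1`, gives > 100000 nM

Compound 1 carries a different core from compound 2, and its result in this assay is a measured number. For compound 2 the reading in this assay is a limit of the assay and not a number: the limit of > 100000 nM in this assay, at which 1 of the 2 values shown sits. Compound 2 thus stands at the edge of what this assay can report, so the size of the gap between it and compound 1 cannot be stated.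

Compound 3, `COc1ccc(OC)c(/C=C/C(=O)N/N=C/c2ccccc2)c1`, has not yet been measured in this assay. It differs from compound 2 in one place: hydrogen in place of chloro on an aromatic carbon. Among the compounds with values here, no measured pair in this set shares that change, so its effect here is unknown. Since compound 2 already sits at the limit, compound 3 is expected to show a step that the limit leaves unreadable from compound 2 to compound 3, which would not reach beyond the usual scatter. Compound 3 is therefore expected to give about 120000 nM in this assay, within 50000 nM to 300000 nM, with a fair chance that this assay again reports only a limit.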

Compound 3, concentration lethal to 50% of the cells: > 100000 nM
Compound 3: no number, only a limit (the forecaster's own chance of this, stated with the estimate: 70%); the middle value does not contradict the limit.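

In this assay compound 3, like compound 2, gives a limit of the assay and not a number, so the step from the 4-chlorophenyl of compound 2 to the phenyl of compound 3 cannot be read: the limit of > 100000 nM in this assay, at which 2 of the 3 values shown sit. The compounds shown leave open whether hydrogen in place of chloro on an aromatic carbon changes this reading at all, and by how much.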